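Working notes: methyl to trifluoromethyl on compound 2

This account rests on a few compounds, and the source may have more. Where it says the series, first, only, none or still open, it means among the compounds named here.

Values so far in a functional assay on A549 cells (Homo sapiens) for inhibition, read by CCK-8 assay, with a stated time of 48 h (on this read-out higher numbers stand for weaker inhibition and lower numbers for stronger inhibition), are as follows.
- compound 1 `COc1cc(-c2cc3nccc(-c4cc(OC)c(OC)c(OC)c4)n3n2)cc(OC)c1OC` gives > 10000 nM as a limit of the assay
- compound 2 `COc1cc(-c2ccnc3cc(-c4ccc(C)cc4)nn23)cc(OC)c1OC` gives 3 nM as a measured number

Among the compounds with values here, compound 2 carries the only actual number in the set, and it stands at 3 nM in this assay with nothing measured to rank it against. Compound 1 reads > 10000 nM in this assay, which is a limit and not a number.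

The next compound, compound 3 `COc1cc(-c2ccnc3cc(-c4ccc(C(F)(F)F)cc4)nn23)cc(OC)c1OC`, has trifluoromethyl in place of methyl on an aromatic carbon on an aromatic carbon of a six-membered aromatic ring of carbon only, para to a large group. The same difference reads as 4-methylphenyl to 4-(trifluoromethyl)phenyl.

Within the data shown here, no measured pair shows a step of this kind, so the expectation rests on compound 2 alone. With compound 2 at 3 nM in this assay, little room is expected for stronger inhibition. A moderate loss is expected, with the estimated change a 6.7-fold higher number from compound 2 to compound 3 (0.82 log units; beyond the scatter) in this assay running toward weaker inhibition. Compound 3 is estimated at 20 nM in this assay, with an expected range from 3 nM to 200 nM on this estimate.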

Compound 3, half-maximal inhibitory concentration: 2070 nM
For compound 3 the middle estimate is 100-fold (2.01 log units) below the measured one; the measured number lies above the stated range.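

In this assay, trifluoromethyl in place of methyl on an aromatic carbon of a six-membered aromatic ring of carbon only, para to a large group, gives a 690-fold higher number from compound 2 to compound 3 (2.84 log units; beyond the scatter). Within the data shown here, this is the first pair that differs in one place, and it shows that this position is far from indifferent to the group it carries: the low number of compound 2 depends on the methyl as well as on the shared core, since everything else stays the same in compound 3. Compound 3 still reads as a number and not as a limit, so the full size of the step can be read, and the read-out has room left over it: the limit of > 10000 nM in this assay, at which 1 of the 3 values shown sits.

A single pair cannot show whether the loss is specific to trifluoromethyl or extends to other groups at this place, such as chlorine, methoxy, ethyl or an amine, so no trend across substituents can be drawn yet. Nothing measured here gives a cause for the size of the step.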